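Swapping the Ester Tail Against a Cytotoxicity Ceiling

The compounds below may be only part of what the source reports. "The series", "measured", "known", "first", "only" and "open" are said of these compounds alone.

The compounds share one core and differ only in the group attached to the oxygen on a saturated carbon. Compound 1 `O=C(OC1CCC(CN2CCN(c3cc(=O)c4cc(C(F)(F)F)cc([N+](=O)[O-])c4s3)CC2)CC1)C1CCC1` carries a cyclobutylcarbonyl there, compound 2 `COc1ccccc1C(=O)OC1CCC(CN2CCN(c3cc(=O)c4cc(C(F)(F)F)cc([N+](=O)[O-])c4s3)CC2)CC1` a (2-methoxyphenyl)carbonyl, and compound 3 `O=c1cc(N2CCN(CC3CCC(OS(=O)(=O)c4cccnc4)CC3)CC2)sc2c([N+](=O)[O-])cc(C(F)(F)F)cc12` a (pyridin-3-yl)sulfonyl. In an ADME assay on Vero cells (Chlorocebus sabaeus) for cytotoxicity, read by MTT assay, with a stated time of 48 h (on this read-out higher numbers stand for weaker inhibition and lower numbers for stronger inhibition), compound 1 reaches only a limit, > 64 ug/mL. In this assay compound 2 likewise gives a limit, > 64 ug/mL. In this assay compound 3 also stops at a limit, > 64 ug/mL. So compound 3 stands where every value so far stands, at the limit of > 64 ug/mL in this assay, at which 3 of the 3 values shown sit; the steps a step that the two limits leave unreadable from compound 1 to compound 2, a step that the two limits leave unreadable from compound 1 to compound 3 and a step that the two limits leave unreadable from compound 2 to compound 3 therefore cannot be sized. Compound 4 `O=C(OC1CCC(CN2CCN(c3cc(=O)c4cc(C(F)(F)F)cc([N+](=O)[O-])c4s3)CC2)CC1)c1ccco1` replaces the tail of compound 3: (furan-2-yl)carbonyl in place of (pyridin-3-yl)sulfonyl on an oxygen on a saturated carbon. Going by the values given here, with no measured step readable, the expectation for this assay is that compound 4 stays at the same ceiling, with a step that the limit leaves unreadable from compound 3 to compound 4 estimated as essentially none. Compound 4 is expected to give about 100 ug/mL, between 40 ug/mL and 300 ug/mL.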

Compound 4, half-maximal inhibitory concentration: > 64 ug/mL
Compound 4 was reported as a limit (the forecaster's own chance of this, stated with the estimate: 85%); the middle value does not contradict the limit.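

Compound 4 also stops at a limit, so no step from compound 1, compound 2 or compound 3 to compound 4 can be read: the limit of > 64 ug/mL in this assay, at which 4 of the 4 values shown sit.

The compounds shown leave open where the true value of each compound lies in this assay, and whether changing the tail shifts it at all.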